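From Compound 2 to Compound 4: a Change at the Aromatic Nitrogen

This account rests on a few compounds, and the source may have more. Where it says the series, first, only, none or still open, it means among the compounds named here.

Of the compounds shown here, three have been measured in a functional assay on FaDu cells (Homo sapiens) for cytotoxicity, read by MTT assay, with a stated time of 72 h; a lower number here means that less compound is tolerated, a higher number that more compound is tolerated. Compound 1 `COc1ccc(NC(=O)C(=O)c2cc(C(C)C)n3ccccc23)cn1` gives 160 nM, compound 2 `COCC(C)n1cc(C(=O)C(=O)Nc2ccc(OC)nc2)c2ccccc21` gives 12 nM, and compound 3 `COc1ccc(NC(=O)C(=O)c2cn(C(C)C)c3ccccc23)nn1` gives 2270 nM. Compound 2 has the lowest number of the three; compound 1 lies nearest to it and compound 3 furthest, both gaps beyond the scatter. Compound 4 `COc1ccc(NC(=O)C(=O)c2cn(C3CCCC3)c3ccccc23)cn1` differs from compound 2 in one place: cyclopentyl in place of 1-(methoxymethyl)ethyl on an aromatic nitrogen. For the measured compounds named here, no measured pair isolates this change, so the expectation rests on the spread of the three numbers alone. A step toward a higher number, beyond the scatter but moderate, is expected; the expected step in this assay is a 2.9-fold higher number from compound 2 to compound 4 (0.46 log units; beyond the scatter). Compound 4 is estimated at 35 nM, with a range from 8 nM to 150 nM.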

Compound 4, concentration lethal to 50% of the cells: 370 nM
For compound 4 the middle estimate is 11-fold (1.02 log units) below the measured one; measured number outside the range, above it.
By their numbers in this assay, from the lowest: compound 2; then compound 1; then compound 4; then compound 3.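

In this assay the group on the aromatic nitrogen proves to matter even at an equal count of heavy atoms: cyclopentyl in place of 1-(methoxymethyl)ethyl gives a 31-fold higher number from compound 2 to compound 4 (1.49 log units; beyond the scatter), a large step. This single change removes the chain's oxygen and introduces a ring of carbon only, so the two alterations cannot be separated here. Nothing available explains the step.

Which alteration carries the step remains open. So does how a longer chain ending in an amine or a carboxylic acid would read at this nitrogen.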